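A few compounds are considered here, and "the series" means these few. Any claim that something is new, unique, unknown or untested is made for them only; others in the source may bear on it.

Two compounds of a shared core carry different arylamide and arylurea groups on the core of compound 1, `COc1cc(-c2nn(-c3cccc(NC(=O)c4cccc(C(F)(F)F)c4)c3)cc2-c2ccncc2)ccc1Cl`, and of compound 2, `COc1cc(-c2nn(-c3cccc(NC(=O)Nc4ccc(Cl)c(Cl)c4)c3)cc2-c2ccncc2)ccc1Cl`. In a functional assay on A549 cells (Homo sapiens) for inhibition, read by sulforhodamine B assay, with a stated time of 48 h (a higher number here means a weaker inhibitor of growth, a lower number a stronger inhibitor of growth), compound 1 gives 1870 nM, and in this assay compound 2 gives 745 nM. Going by the values given here, the only measured step is a 2.5-fold lower number from compound 1 to compound 2 (0.40 log units; beyond the scatter), and it changes two things at once: the group on the carbonyl carbon and the aryl group itself. Compound 2 therefore stands as the lower of the two numbers, with compound 1 the nearest neighbour beyond the scatter.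

Compound 3, `COc1cc(-c2nn(-c3cccc(NC(=O)Nc4cccc(C(F)(F)F)c4)c3)cc2-c2ccncc2)ccc1Cl`, moves in a single place: 3-(trifluoromethyl)phenyl in place of 3,4-dichlorophenyl on an amide-type nitrogen. This step keeps the urea linkage of compound 2 and restores the aryl group of compound 1, so it splits the earlier step into its two parts. Among the compounds with values here, no measured step tells how the aryl group alone acts on a urea, and compound 1 shows the same aryl group only on an amide. The account expects compound 3 to sit between the two measured values, a step of a 1.5-fold higher number from compound 2 to compound 3 (0.17 log units; within the scatter) in this assay, and estimates compound 3 at 1100 nM with a range from 450 nM to 2800 nM.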

Compound 3, concentration for 50% growth inhibition: 794 nM
Compound 3: middle estimate off by 1.4-fold (0.14 log units), on the high side; the range from low to high includes it.
By their numbers in this assay, from the lowest: compounds 2 and 3 (each within the scatter of the next); then compound 1.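

In this assay, exchanging 3,4-dichlorophenyl for 3-(trifluoromethyl)phenyl on the amide-type nitrogen of the urea gives a 1.1-fold higher number from compound 2 to compound 3 (0.03 log units; within the scatter) and thus no difference that can be read between these two aryl groups at this place, even though they differ in their heavy atoms. The other new step keeps the aryl group fixed and replaces 3-(trifluoromethyl)phenyl on a carbonyl carbon with (3-(trifluoromethyl)phenyl)amino, giving a 2.4-fold lower number from compound 1 to compound 3 (0.37 log units; beyond the scatter) and thereby separating the two changes that the earlier step joined: among these three compounds, the difference beyond the scatter goes with the change from amide to urea and not with the exchange of aryl groups. No measurement offered here accounts for either step.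

Going by these compounds alone, only two aryl groups stand on the urea nitrogen, so it remains open whether a cyclohexyl group, a pyridine ring or a methoxyphenyl group at that place would give a similar number. Within the data shown here, the change from amide to urea is also read with only one aryl group, 3-(trifluoromethyl)phenyl, and whether the same step holds with another aryl group remains open.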